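Series notes: the step from compound 2 to compound 3

This account rests on a few compounds, and the source may have more. Where it says the series, first, only, none or still open, it means among the compounds named here.

Two compounds of the series carry numbers in an ADME assay on J774 cells (Mus musculus) for cytotoxicity, read by MTT assay, with a stated time of 48 h, tested at 150 ug/mL; on this read-out lower numbers stand for a stronger effect and higher numbers for a weaker effect at the one concentration tested. Compound 1 `O=C(N/N=C/c1ccccc1)c1cnccn1` gives 100% in this assay, and compound 2 `O=C(N/N=C/c1ccc(Cl)cc1)c1cnccn1` gives 56%. On these two numbers compound 2 stands lowest; its nearest neighbour is compound 1, and the step of a number 44 percentage points lower from compound 1 to compound 2 (beyond the scatter) lies beyond the scatter. Among the compounds with values here, that step, chloro in place of hydrogen on an aromatic carbon, is the only measured step so far.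

Compound 3 `O=C(N/N=C/c1ccc(F)cc1)c1cnccn1` has not yet been measured. Against compound 2 it differs in one place: fluoro in place of chloro on an aromatic carbon. The measured step bears on it only indirectly, since it concerns chloro entering for hydrogen, whereas here chloro leaves and fluoro enters. Within the data shown here, no measured pair sets fluoro against chloro, so the expectation rests on compound 1 sitting at 100% and compound 2 at 56%. A modest step upward, a number 19 percentage points higher from compound 2 to compound 3 (beyond the scatter), is expected for compound 3, smaller than the measured a number 44 percentage points lower from compound 1 to compound 2 (beyond the scatter). Compound 3 is therefore estimated at 75%, with a range from 50% to 100%.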

Compound 3, a percentage reported as activity, at one concentration (the size of the read-out at that concentration, not a potency): 71%
Compound 3: the middle estimate sits 4 percentage points above what was measured; measured number inside the range.
By their numbers in this assay, from the lowest: compound 2; then compound 3; then compound 1.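

In this assay, the position on an aromatic carbon para to a large group responds to which halogen it carries and not merely to whether a halogen is present, since the exchange of chloro for fluoro gives a number that lies apart from that of the chloro compound, with a number 15 percentage points higher from compound 2 to compound 3 (beyond the scatter) as the step. Fluoro still separates from hydrogen at the same place, with a number 29 percentage points lower from compound 1 to compound 3 (beyond the scatter) as the step, so among these three compounds the read-out falls on moving from hydrogen to fluoro and again on moving from fluoro to chloro, with no compound of the three going against that order. Nothing measured explains why the two halogens differ here, and no supporting data bear on these numbers.

The compounds shown leave open whether this order extends to other groups at the same place, such as bromo, methoxy, an amine or a carboxylic acid. They also leave open whether fluoro or chloro would give similar numbers on another aromatic carbon of the ring, and how these readings at one concentration would relate to a full concentration response.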